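The source may report more compounds than this note shows. Statements on the series, on what has been measured and on what is new or still open speak of the compounds shown alone.

Compound 3, `Cn1c(=O)c(S(=O)(=O)c2ccc(O)cc2)cc2cnc(Nc3ccc4[nH]ccc4c3)nc21`, gives the lowest number of the three compounds measured in a functional assay on K562 cells (Homo sapiens) for inhibition, read by trypan blue exclusion, with a stated time of 72 h; on this read-out lower numbers stand for stronger inhibition and higher numbers for weaker inhibition; in this assay compound 3 gives 100 nM. Compound 1, `Cn1c(=O)c(S(=O)(=O)c2ccc(F)cc2[N+](=O)[O-])cc2cnc(Nc3ccc4[nH]ccc4c3)nc21`, gives 900 nM in this assay, and compound 2, `Cn1c(=O)c(S(=O)(=O)Cc2ccc(F)cc2F)cc2cnc(Nc3ccc4[nH]ccc4c3)nc21`, gives 1000 nM. The two steps that lead to compound 3 are a 9.0-fold lower number from compound 1 to compound 3 (0.95 log units; beyond the scatter) and a 10-fold lower number from compound 2 to compound 3 (1.00 log units; beyond the scatter), while the step of a 1.1-fold higher number from compound 1 to compound 2 (0.05 log units; within the scatter) lies within the scatter.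

Compound 4, `Cn1c(=O)c(S(=O)(=O)c2ccc(F)cc2N)cc2cnc(Nc3ccc4[nH]ccc4c3)nc21`, has not yet been measured in this assay. It differs from compound 3 in one place: 2-amino-4-fluorophenyl in place of 4-hydroxyphenyl on a sulfonyl sulfur. For the measured compounds named here, the group that enters shares the fluorine on the ring with the group carried by compound 1, so the step from compound 3 to compound 4 runs partly back toward compound 1, although no measured step reports an amino group in this position. The step of a 9.0-fold lower number from compound 1 to compound 3 (0.95 log units; beyond the scatter) is the one that bears most on it, and compound 4 is therefore expected to sit between compound 3 and compound 1, with a higher number than compound 3 and a step of a 3.5-fold higher number from compound 3 to compound 4 (0.54 log units; beyond the scatter). Compound 4 is estimated at 350 nM in this assay, with a range from 120 nM to 1000 nM.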

Compound 4, half-maximal inhibitory concentration: 2000 nM
Estimate against measurement, compound 4: 5.7-fold (0.76 log units) below, and the stated range ends below it.
By their numbers in this assay, from the lowest: compound 3; then compounds 1, 2 and 4 (each within the scatter of the next, the first and the last beyond it).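

For the compounds shown here, the largest step so far is a 20-fold higher number from compound 3 to compound 4 (1.30 log units; beyond the scatter), and it shows that the low number of compound 3 does not carry over to a sulfonyl sulfur bearing 2-amino-4-fluorophenyl, even though this group keeps an aromatic ring directly on the sulfur. Amino in place of nitro on an aromatic carbon does not move the number toward that of compound 3 but away from it, in a 2.2-fold higher number from compound 1 to compound 4 (0.35 log units; beyond the scatter), while a 2.0-fold higher number from compound 2 to compound 4 (0.30 log units; within the scatter) leaves compound 4 level with the difluorobenzyl compound, so that all three fluorine-bearing groups now sit well above compound 3 whichever other group accompanies the fluorine. Nothing given here accounts for these differences.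

Going by these compounds, the step to compound 4 removes the hydroxy group and adds both the amino group and the fluorine at once, so the share of each in the loss stays open. Whether the hydroxy group alone sets the low number could be told from an unsubstituted phenyl, a 4-methoxyphenyl, a 4-aminophenyl or a 4-fluorophenyl group on the same sulfonyl sulfur.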